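The source may hold more compounds than are shown below. What is called first, only, known or untested is meant among the compounds shown, and "the series" means these compounds.

Going by the values given here, in an ADME assay on MCF7 cells (Homo sapiens) for cytotoxicity, read by MTT assay, with a stated time of 48 h (a higher number here means a weaker inhibitor, a lower number a stronger inhibitor), compound 2 `Fc1ccc(-c2[nH]c3cc(Cl)ccc3c2Cn2cncn2)cc1` gives 625000 nM, the only actual number so far. Compound 1 `COc1ccc2c(Cn3ccnc3)c(-c3ccc(F)cc3)[nH]c2c1`, which bears methoxy, is reported only as a limit, > 1000000 nM. Compound 3 `COc1ccc2c(Cn3cncn3)c(-c3ccc(F)cc3)[nH]c2c1` keeps the azole of compound 2 but carries methoxy in place of chloro on an aromatic carbon, (methoxy in place of chloro on an aromatic carbon). Among the compounds with values here, no measured step isolates this change, so only a small shift toward weaker values, within the usual scatter of this assay, is expected, the estimated 1.4-fold higher number from compound 2 to compound 3 (0.13 log units; within the scatter). Compound 3 is estimated at 850000 nM, with an expected range of 400000 nM to 1600000 nM.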

Compound 3, half-maximal inhibitory concentration: 12200 nM
Beside the measured number, compound 3's estimate is 70-fold (1.84 log units) above it; measured number below the stated range.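

In this assay, methoxy in place of chloro on an aromatic carbon of the six-membered aromatic ring of carbon only is a large change, with a 51-fold lower number from compound 2 to compound 3 (1.71 log units; beyond the scatter). With methoxy held, 1H-1,2,4-triazol-1-yl in place of 1H-imidazol-1-yl on the saturated chain carbon is also large, with an at least 81-fold lower number from compound 1 to compound 3 (1.91 log units; beyond the scatter). That second step rests on a limit for compound 1, not on a number: the limit of > 1000000 nM in this assay, at which 1 of the 3 values shown sits.

On these data alone, whether a hydroxyl, an amine or a longer alkoxy chain on that aromatic carbon would match methoxy remains open. So does whether the methoxy step holds with 1H-imidazol-1-yl in place of the triazole.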